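The source may hold more compounds than are shown below. What is called first, only, known or untested is meant among the compounds shown, and "the series" means these compounds.

Working notes on the series

Compound 1 `CS(=O)(=O)c1ccc(Cc2n[nH]c(=S)n2/N=C/c2c(F)cccc2Cl)cc1` carries the shared core with a 2-chloro-6-fluorophenyl group on the carbon double-bonded to nitrogen. Among the compounds with values here, in a functional assay on HeLa cells (Homo sapiens) for cytotoxicity, read by MTT assay, with a stated time of 48 h, tested at 25 uM (a higher number here means a stronger effect of the compound at the concentration tested, a lower number a weaker effect), compound 1 gives 55.3%, the highest of the three numbers measured so far. Compound 3 `CS(=O)(=O)c1ccc(Cc2n[nH]c(=S)n2/N=C/c2ccccc2Cl)cc1` keeps only the chloro substituent and gives 36.3% in this assay; the step is a number 19 percentage points lower from compound 1 to compound 3 (beyond the scatter). Compound 2 `CS(=O)(=O)c1ccc(Cc2n[nH]c(=S)n2/N=C/c2cccnc2)cc1` carries pyridin-3-yl and gives 19.4% in this assay, with a number 35.9 percentage points lower from compound 1 to compound 2 (beyond the scatter). From compound 2 to compound 3 the change is a number 16.9 percentage points higher from compound 2 to compound 3 (beyond the scatter).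

Compound 4 `CS(=O)(=O)c1ccc(Cc2n[nH]c(=S)n2/N=C/c2cccs2)cc1` has not been measured. Its difference from compound 1 is thiophen-2-yl in place of 2-chloro-6-fluorophenyl on a carbon with a double bond to nitrogen. Within the data shown here, both of the halogen-bearing phenyl compounds, compound 1 and compound 3, sit above the one compound with a heteroaromatic ring, compound 2. Compound 4 loses both halogens and brings in a five-membered ring with one hetero atom, so the closest guide is the large drop seen in a number 35.9 percentage points lower from compound 1 to compound 2 (beyond the scatter), tempered by the smaller loss in a number 19 percentage points lower from compound 1 to compound 3 (beyond the scatter). A downward step beyond the scatter in this assay is therefore expected.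

For compound 4 the expected step is a number 29.3 percentage points lower from compound 1 to compound 4 (beyond the scatter). Compound 4 is estimated to give 26% in this assay, within 10% to 45%.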

Compound 4, a percentage reported as activity, at one concentration (the size of the read-out at that concentration, not a potency): 33.3%
The estimate for compound 4 lay 7.3 percentage points below the measured number, within the range that was stated.
By their numbers in this assay, from the lowest: compound 2; then compounds 4 and 3 (each within the scatter of the next); then compound 1.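

The new compound shows that a heteroaromatic ring on the carbon with a double bond to nitrogen does not fix a single low level in this assay, since the change of ring alone gives a number 13.9 percentage points higher from compound 2 to compound 4 (beyond the scatter) and so separates thiophen-2-yl from pyridin-3-yl. Thiophen-2-yl, which carries no halogen, also cannot be told apart from 2-chlorophenyl, with a number 3 percentage points lower from compound 3 to compound 4 (within the scatter) as the step, so a chloro-substituted phenyl ring is not needed to reach that level. Only the 2-chloro-6-fluorophenyl group remains clear of thiophen-2-yl among these pairs, with a number 22 percentage points lower from compound 1 to compound 4 (beyond the scatter) as the modest step, and no measurement at hand accounts for any of these differences.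

The compounds shown leave open where an unsubstituted phenyl ring or a 2-fluorophenyl ring would fall in this series. They also leave open whether a saturated cyclohexyl ring, a longer alkyl chain, or a phenyl ring carrying an amine or a carboxylic acid could stand at this carbon and keep the effect seen with compound 1.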